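Trimming the Chain: From Compound 1 to Compound 4

This account rests on a few compounds, and the source may have more. Where it says the series, first, only, none or still open, it means among the compounds named here.

Of the compounds shown here, three sharing one core have been tested in a functional assay on CCRF-CEM cells (Homo sapiens) for inhibition, read by MTT assay, with a stated time of 72 h; on this read-out lower numbers stand for stronger inhibition and higher numbers for weaker inhibition. Compound 1 `COc1cc(NC(C)CCCNC(=O)NNC(=O)Nc2cccc(F)c2)c2ncccc2c1` gives 98000 nM, the second highest of the three numbers. Compound 2 `COc1cc(NC(C)CCCNC(=O)NNC(=O)Nc2ccc(Br)cc2)c2ncccc2c1` gives 110000 nM, and the step of a 1.1-fold higher number from compound 1 to compound 2 (0.05 log units; within the scatter) lies within the scatter. Compound 3 `COc1cc(NC(C)CCCNC(=O)Nc2ccc(O)cc2)c2ncccc2c1` gives 23000 nM, the lowest of the three; the steps of a 4.3-fold lower number from compound 1 to compound 3 (0.63 log units; beyond the scatter) and a 4.8-fold lower number from compound 2 to compound 3 (0.68 log units; beyond the scatter) are modest but beyond the scatter, and in each a carbamoylamino unit on the amide-type nitrogen is replaced by a single ring group.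

Compound 4 `COc1cc(NC(C)CCCNC(=O)Nc2cccc(Cl)c2)c2ncccc2c1` awaits measurement. It differs from compound 1 as 3-chlorophenyl in place of ((3-fluorophenyl)carbamoyl)amino on an amide-type nitrogen. Among the compounds with values here, as in the two measured steps, the ((3-fluorophenyl)carbamoyl)amino unit is removed, though here 3-chlorophenyl enters rather than 4-hydroxyphenyl, and no measured pair shows how those two ring groups compare. Since both comparable steps lowered the number modestly and beyond the scatter, a lowering of similar size is expected, namely a 3.9-fold lower number from compound 1 to compound 4 (0.59 log units; beyond the scatter). Compound 4 is therefore estimated to give 25000 nM in this assay, within a range from 8000 nM to 80000 nM.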

Compound 4, half-maximal inhibitory concentration: 22000 nM
Compound 4: the middle estimate sits 1.1-fold (0.06 log units) above what was measured; the measured number falls inside the stated range.
By their numbers in this assay, from the lowest: compounds 4 and 3 (each within the scatter of the next); then compounds 1 and 2 (each within the scatter of the next).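

In this assay, 3-chlorophenyl in place of ((3-fluorophenyl)carbamoyl)amino on the amide-type nitrogen gives the same kind of shift seen before (a 4.5-fold lower number from compound 1 to compound 4 (0.65 log units; beyond the scatter)), and the comparison with the bromine-bearing compound agrees (a 5.0-fold lower number from compound 2 to compound 4 (0.70 log units; beyond the scatter)). The lower number is therefore not tied to 4-hydroxyphenyl: among these four compounds, both with a single ring group on that nitrogen sit lower than both with the carbamoylamino unit, and none goes against this, while the two ring groups themselves cannot be told apart (a 1.0-fold lower number from compound 3 to compound 4 (0.02 log units; within the scatter)). No measured evidence is available on why the numbers differ.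

The compounds shown leave open what a carboxylic acid or an amine on that ring, in place of chlorine or hydroxyl, would do to the number. They also leave open whether a longer chain between the core and this nitrogen would lower it further.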